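Swapping a Pyridine for a Furan on the Amide Carbonyl

The source may hold more compounds than are shown below. What is called first, only, known or untested is meant among the compounds shown, and "the series" means these compounds.

Compound 2 `Cc1cccc(Cn2c(CN3CCN(C(=O)c4ccncc4)CC3)nc3ccccc32)c1` stands second highest of three compounds in an assay on isolated protein for inhibition of aldehyde dehydrogenase 1A1 (Homo sapiens), read by spectrophotometry, tested at 10 uM (a higher number here means more inhibition at the concentration tested (going by the name of the read-out), a lower number less inhibition), where compound 2 gives 20.6%. Closest in value is compound 3 `CC(C)Cn1c(CN2CCN(C(=O)C3CC3)CC2)nc2ccccc21`, which in this assay gives 13.1%; these two numbers lie within the usual scatter, so nothing separates them. Furthest away is compound 1 `CC(=O)N1CCN(Cc2nc3ccccc3n2Cc2cccc(C)c2)CC1`, which in this assay gives 70.3%.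

Compound 4 `Cc1cccc(Cn2c(CN3CCN(C(=O)c4ccco4)CC3)nc3ccccc32)c1` has not yet been measured. It differs from compound 2 in one place: furan-2-yl in place of pyridin-4-yl on a carbonyl carbon. For the measured compounds named here, only one measured step touches this carbonyl carbon: a number 49.7 percentage points lower from compound 1 to compound 2 (beyond the scatter), in which pyridin-4-yl took the place of methyl. That step was large, but it compares an aromatic ring with a methyl group, whereas here one aromatic ring replaces another. Going by the values given here, no measured pair contains a furan-2-yl at this place, so neither the direction nor the size of the change can be read from the data, and the large drop seen from compound 1 to compound 2 gives no guide for an exchange between two rings.

The step of a number 3.4 percentage points higher from compound 2 to compound 4 (within the scatter) is therefore expected to remain within the scatter. Compound 4 is estimated to give about 24% in this assay, with a range from 8% to 45%.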

Compound 4, a percentage reported as inhibition, at one concentration (the size of the read-out at that concentration, not a potency): 73.2%
Estimate against measurement, compound 4: 49.2 percentage points below; measured number above the stated range.
By their numbers in this assay, from the lowest: compounds 3 and 2 (each within the scatter of the next); then compounds 1 and 4 (each within the scatter of the next).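

In this assay, the group on this carbonyl carbon matters even when one aromatic ring replaces another: the exchange of pyridin-4-yl for furan-2-yl gives a large change (a number 52.6 percentage points higher from compound 2 to compound 4 (beyond the scatter)). The low number of compound 2 therefore does not apply to every aromatic ring at this place, and the earlier drop from methyl cannot be read as the effect of simply adding a ring. Furan-2-yl and methyl, by contrast, cannot be told apart here (a number 2.9 percentage points higher from compound 1 to compound 4 (within the scatter)), so this place accepts at least one five-membered aromatic ring with no measurable change from the methyl compound, while the two rings, each with one hydrogen-bond acceptor by count, still give very different numbers, and nothing available accounts for that gap.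

The compounds shown leave open whether a phenyl, thiophen-2-yl or furan-3-yl group on this carbonyl carbon would stay level with compound 4 or fall toward compound 2, and so whether pyridin-4-yl is an isolated case. They also leave open whether furan-2-yl would hold its number with a different group elsewhere on the shared core, such as a plain benzyl group.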